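Replacing 4-Phenylphenyl with 2-Methylphenyl: Cytotoxicity Outlook

This account rests on a few compounds, and the source may have more. Where it says the series, first, only, none or still open, it means among the compounds named here.

Compound 1 `COC(=O)c1ccc(NCc2cncn2Cc2cccc(Cl)c2)cc1-c1ccccc1` — in a toxicity assay on NIH3T3 cells (Mus musculus) for cytotoxicity, read by resazurin assay (on this read-out lower numbers stand for an effect already at smaller amounts and higher numbers for an effect only at larger amounts of compound), a limit: > 10000 nM.
Compound 2 `COC(=O)c1ccc(NCc2cncn2Cc2cccc(C#N)c2)cc1-c1ccccc1` — in this assay a limit: > 10000 nM.
Compound 3 `COC(=O)c1ccc(NCc2cncn2Cc2ccc(-c3ccccc3)cc2)cc1-c1ccccc1` — in this assay a limit: > 1000 nM.

Compound 3 stands only at a limit. The same holds for the other two values, at the limit of > 10000 nM in this assay, at which 2 of the 3 values shown sit, while compound 3 sits at the limit of > 1000 nM in this assay, at which 1 of the 3 values shown sits. Compound 4 `COC(=O)c1ccc(NCc2cncn2Cc2ccccc2C)cc1-c1ccccc1` differs from compound 3 in one place: 2-methylphenyl in place of 4-phenylphenyl on a saturated chain carbon bound to an aromatic nitrogen. Among the measured compounds shown here, the steps that bear on this change are a step that the two limits leave unreadable from compound 1 to compound 3 and a step that the two limits leave unreadable from compound 2 to compound 3, and a step that the two limits leave unreadable from compound 1 to compound 2 adds nothing readable either. None of these steps gives a size or direction to lean on. The step that the limit leaves unreadable from compound 3 to compound 4 is therefore purely an expectation of my own. Compound 4 is expected to give 10000 nM, with a range from 3000 nM to 30000 nM, most likely again as a limit.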

Compound 4, half-maximal effective concentration: 10000 nM
Compound 4: the middle estimate sits on the measured number at the digits printed; the range from low to high includes it.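

In this assay compound 4 is the only compound shown with a plain number rather than a limit, so 2-methylphenyl gives this position its first exact reading. Among the compounds shown here, the earlier limits allow only a number no higher from compound 1 to compound 4 (the limit leaves the size open) and a number no higher from compound 2 to compound 4 (the limit leaves the size open), and no step here can be read for size. Compound 3 remains a limit: the limit of > 1000 nM in this assay, at which 1 of the 4 values shown sits.

From the compounds shown here alone, how much the change from 4-phenylphenyl moves the number stays open. So does the reading for a phenyl ring carrying an amine or a carboxylic acid at this place.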